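This account rests on a few compounds, and the source may have more. Where it says the series, first, only, none or still open, it means among the compounds named here.

Measured compounds:
- Compound 1 `O=C1/C(=C/c2cccnc2)CN(S(=O)(=O)c2ccccc2)C/C1=C\c1ccccc1F`: 4800 nM
- Compound 2 `Cc1ccc(S(=O)(=O)N2C/C(=C\c3cccnc3)C(=O)/C(=C/c3ccccc3F)C2)cc1`: 9700 nM
- Compound 3 `O=C1/C(=C/c2cccnc2)CN(S(=O)(=O)c2ccc(C(F)(F)F)cc2)C/C1=C\c1ccccc1F`: 4500 nM

In a functional assay on QGY-7703 cells (Homo sapiens) for cytotoxicity, read by MTT assay, with a stated time of 24 h (on this read-out lower numbers stand for stronger inhibition and higher numbers for weaker inhibition), compound 3 gives 4500 nM. It stands level with compound 1, as a 1.1-fold lower number from compound 1 to compound 3 (0.03 log units; within the scatter) shows, and clearly apart from the remaining measured compound, with a 2.2-fold lower number from compound 2 to compound 3 (0.33 log units; beyond the scatter).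

The next molecule, compound 4 `O=C1/C(=C/c2ccncc2)CN(S(=O)(=O)c2ccc(C(F)(F)F)cc2)C/C1=C\c1ccccc1F`, differs from compound 3 in one place: pyridin-4-yl in place of pyridin-3-yl on a double-bonded chain carbon bound to a double-bonded ring carbon. The same atoms are simply joined differently.

Going by the values given here, no measured step tests this swap. All three measured compounds carry pyridin-3-yl, and their steps change a group on an aromatic carbon elsewhere. The largest of these, a 2.2-fold lower number from compound 2 to compound 3 (0.33 log units; beyond the scatter), is modest, and a 2.0-fold higher number from compound 1 to compound 2 (0.31 log units; beyond the scatter) is similar, so they serve only as a rough guide to how far numbers move in this small set.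

With no evidence on direction, no shift beyond the scatter is expected in this assay, and the estimated change is a 1.1-fold higher number from compound 3 to compound 4 (0.05 log units; within the scatter). For compound 4 the expected value is 5000 nM, with an estimated range of 2200 nM to 11000 nM.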

Compound 4, half-maximal inhibitory concentration: 9500 nM
Estimate against measurement, compound 4: 1.9-fold (0.28 log units) below; measured number inside the range.
By their numbers in this assay, from the lowest: compounds 3, 1, 4 and 2 (each within the scatter of the next, the first and the last beyond it).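

Going by these compounds alone, replacing pyridin-3-yl with pyridin-4-yl on this double-bonded chain carbon is the first change tested at this position, and in this assay it gives a modest shift beyond the scatter (a 2.1-fold higher number from compound 3 to compound 4 (0.32 log units; beyond the scatter)). So the way the pyridine ring is joined matters here, even though the two groups contain the same atoms, and this rearrangement moves the number about as far as replacing methyl with trifluoromethyl on an aromatic carbon (a 2.2-fold lower number from compound 2 to compound 3 (0.33 log units; beyond the scatter)). No measurement shown here gives a reason for the difference.

As far as these compounds go, how pyridin-2-yl or a plain phenyl group would behave at this position remains open. So does whether the switch to pyridin-4-yl gives a similar shift when hydrogen or methyl replaces the trifluoromethyl group of compound 4.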